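Adding a Third Methoxy Group to the Aryl Ketone Ring

This account rests on a few compounds, and the source may have more. Where it says the series, first, only, none or still open, it means among the compounds named here.

Compound 2 `COc1ccc(C(=O)/C=C/c2cc(-c3cc(OC)c(OC)c(OC)c3)n[nH]2)cc1OC` holds the lower of the two numbers measured in a functional assay on KM12 cells (Homo sapiens) for cytotoxicity, read by sulforhodamine B assay, with a stated time of 48 h, tested at 1 uM; a higher number here means a weaker effect of the compound at the concentration tested, a lower number a stronger effect: compound 2 gives 54%, whereas compound 1 `COc1cc(-c2cc(/C=C/C(=O)c3ccc(Cl)c(Cl)c3)[nH]n2)cc(OC)c1OC` gives 85%. For the measured compounds named here, the only measured step, a number 31 percentage points lower from compound 1 to compound 2 (beyond the scatter), put 3,4-dimethoxyphenyl in place of 3,4-dichlorophenyl on the carbonyl carbon. Compound 3 `COc1cc(C(=O)/C=C/c2cc(-c3cc(OC)c(OC)c(OC)c3)n[nH]2)cc(OC)c1OC` alters that same ring once more: methoxy in place of hydrogen on an aromatic carbon. The added group sits on an aromatic carbon of a six-membered aromatic ring of carbon only, ortho to a methoxy group and meta to a large group and to a methoxy group. Going by the values given here, no measured step adds or removes a methoxy group on this ring, so the step from a number 31 percentage points lower from compound 1 to compound 2 (beyond the scatter) bears on the question only loosely; it shows that exchanging the substituents of this ring can move the read-out a great deal, but it does not tell in which direction a further methoxy group pushes. One therefore expects a step of a number 6 percentage points lower from compound 2 to compound 3 (within the scatter) in this assay, modest or within the scatter, and estimates compound 3 at 48%, within 25% to 75%.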

Compound 3, a percentage reported as activity, at one concentration (the size of the read-out at that concentration, not a potency): 79%
Estimate against measurement, compound 3: 31 percentage points below, outside the stated range (above it).
By their numbers in this assay, from the lowest: compound 2; then compounds 3 and 1 (each within the scatter of the next).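

The added methoxy group, ortho to a methoxy group on the aryl ketone ring, gives a number 25 percentage points higher from compound 2 to compound 3 (beyond the scatter) in this assay; this position therefore responds to the change, and the extra group goes with a weaker effect at the concentration tested. The earlier step showed only that exchanging the substituents of this ring can move the read-out, whereas this one gives a direction for one methoxy group added to the dimethoxyphenyl ring, leaving compound 2 the strongest of the three, while compound 3 at 79% and compound 1 at 85% lie within the scatter of each other. Nothing in the data shown explains why the read-out responds in this way.

As far as these compounds go, it remains open whether a hydroxyl or an ethoxy group on this same aromatic carbon would go the same way as methoxy, or whether a smaller atom such as fluorine would leave the read-out where compound 2 has it. An amine at this carbon is equally untested among the compounds shown, so the step describes this one methoxy group and no wider rule for the ring.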